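Amide nitrogen variation in a two-compound series

This account rests on a few compounds, and the source may have more. Where it says the series, first, only, none or still open, it means among the compounds named here.

Measured so far:
compound 1 `O=C(Oc1ccc(-c2ccc(F)cc2F)cc1C(=O)O)c1ccccc1`, 16.1%
compound 2 `CNC(=O)c1cc(-c2ccc(F)cc2F)ccc1OC(C)=O`, 48.8%

In a functional assay on the whole organism (Ear) for inhibition, with Mus musculus as the target, at a dose of 40 mg/kg by the oral route (on this read-out higher numbers stand for more inhibition at the one dose given (going by the name of the read-out) and lower numbers for less inhibition), compound 2 gives 48.8%, the higher of the two numbers; compound 1 lies lower by a gap beyond the scatter. Compound 3 `CC(=O)Oc1ccc(-c2ccc(F)cc2F)cc1C(=O)NC1CCCCC1` differs from compound 2 in one place: cyclohexyl in place of methyl on an amide-type nitrogen. Within the data shown here, no measured pair carries this difference, so its effect here is unknown. A step of no more than the usual scatter is expected, in either direction, a number 3.8 percentage points lower from compound 2 to compound 3 (within the scatter). Compound 3 is thus expected to give about 45%, in the range 20% to 70%.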

Compound 3, a percentage reported as inhibition, in the whole organism at one dose (the size of the read-out at that dose, not a potency): 0%
Estimate against measurement, compound 3: 45 percentage points above, outside the stated range (below it).
By their numbers in this assay, from the lowest: compound 3; then compound 1; then compound 2.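

At this amide-type nitrogen the substituent matters strongly in this assay: cyclohexyl in place of methyl gives a number 48.8 percentage points lower from compound 2 to compound 3 (beyond the scatter). Among these compounds, the earlier compounds offered no pair that isolated this position, so this is the first direct reading of it, and methyl is the better of the two groups tested. Nothing available explains the size of this step.

Open, as far as these compounds go, is how the read-out behaves between these two groups, for example with ethyl or a longer open chain on the same nitrogen. Also open, from the compounds shown here alone, is whether an amine-bearing chain or a cyclopropyl there would hold the read-out.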